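Heteroaryl swap on the shared core: thiophene to furan

The compounds below may be only part of what the source reports. "The series", "measured", "known", "first", "only" and "open" are said of these compounds alone.

Measured so far in a functional assay on T47D cells (Homo sapiens) for cytotoxicity, read by CCK-8 assay and cell counting, with a stated time of 2 days; a higher number here means a weaker inhibitor, a lower number a stronger inhibitor:
compound 1 `Oc1ccc(-c2cc(-c3ccc(Cl)cc3)nc(-c3ccsc3)c2)cc1`: 5490 nM
compound 2 `Oc1cccc(-c2cc(-c3ccc(Cl)cc3)nc(-c3ccsc3)c2)c1`: 11500 nM
compound 3 `Oc1ccc(-c2cc(-c3ccsc3)nc(-c3cccc(Cl)c3)c2)cc1`: 7390 nM

Compound 1 gives the lowest number of the three. Its nearest neighbour is compound 3, where a 1.3-fold higher number from compound 1 to compound 3 (0.13 log units; within the scatter); the furthest is compound 2, where a 2.1-fold higher number from compound 1 to compound 2 (0.32 log units; beyond the scatter). Compound 4 `Oc1ccc(-c2cc(-c3ccc(Cl)cc3)nc(-c3ccco3)c2)cc1` keeps the 4-chlorophenyl and 4-hydroxyphenyl groups of compound 1 and changes only the five-membered ring: furan-2-yl in place of thiophen-3-yl on an aromatic carbon.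

Neither measured step touches this position. The step from compound 1 to compound 2 moves the hydroxyl, the step from compound 1 to compound 3 moves the chlorine, and both leave the thiophen-3-yl group in place. Among the measured compounds shown here, no measured pair therefore bears directly on the thiophene-to-furan exchange, and the two steps that exist are small to modest. With nothing pointing in either direction, no step beyond the scatter is expected for a 1.0-fold higher number from compound 1 to compound 4 (0.00 log units; within the scatter) in this assay. The estimate for compound 4 is 5500 nM, with a range from 2500 nM to 13000 nM, the width reflecting the absence of a precedent for this change.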

Compound 4, half-maximal inhibitory concentration: 6260 nM
Estimate against measurement, compound 4: 1.1-fold (0.06 log units) below, and the stated range covers the measured number.
By their numbers in this assay, from the lowest: compounds 1, 4, 3 and 2 (each within the scatter of the next, the first and the last beyond it).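

In this assay, replacing thiophen-3-yl with furan-2-yl on the aromatic carbon next to the ring nitrogen gives a 1.1-fold higher number from compound 1 to compound 4 (0.06 log units; within the scatter). Unlike the earlier steps, which moved the hydroxyl or the chlorine, this one changes the five-membered ring itself, and with the 4-chlorophenyl and 4-hydroxyphenyl groups held fixed, the exchange of sulfur for oxygen and the shift in attachment point together leave the number within the scatter. No available data explain this outcome.

As far as these compounds go, the exchange alters the hetero atom and the attachment point at once, so the effect of each alone remains open, and thiophen-2-yl and furan-3-yl would separate the two. Also open, from the compounds shown here alone, is how this position responds to groups other than a five-membered aromatic ring, such as a morpholine or a primary amine.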